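This account rests on a few compounds, and the source may have more. Where it says the series, first, only, none or still open, it means among the compounds named here.

Measured compounds:
compound 1 `COc1cc(/C=C/C(=O)C2=C(/C=C/c3ccc(O)c(OC)c3)NC(=O)NC2c2ccc(O)cc2)ccc1O` – 72%
compound 2 `COc1cc(/C=C/C(=O)C2=C(/C=C/c3ccc(O)c(OC)c3)NC(=O)NC2c2ccc(N(C)C)cc2)ccc1O` – 69.9%

In a functional assay, with a stated time of 20 min, tested at 10 uM (a higher number here means a stronger effect of the compound at the concentration tested, a lower number a weaker effect), compound 1 gives 72% and compound 2 gives 69.9%; the step of a number 2.1 percentage points lower from compound 1 to compound 2 (within the scatter) places the two within the scatter of each other, so compound 2 stands level with compound 1 on the numbers shown, with no ordering to be read from them.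

Compound 3 `COc1cc(/C=C/C(=O)C2=C(/C=C/c3ccc(O)c(OC)c3)NC(=O)NC2c2c(Cl)cccc2Cl)ccc1O` is not yet measured. Its change from compound 2 is 2,6-dichlorophenyl in place of 4-(dimethylamino)phenyl on a saturated ring carbon. Among the compounds with values here, the only measured step, a number 2.1 percentage points lower from compound 1 to compound 2 (within the scatter), also alters the group on that saturated ring carbon, and it was within the scatter. Nothing measured covers the entry of the 2,6-dichlorophenyl group, so the expectation rests on that single level step: in this assay no step beyond the scatter is expected, with a wide range to allow for the untested group. Compound 3 is therefore expected at 65%, between 45% and 80%. The expected step is a number 4.9 percentage points lower from compound 2 to compound 3 (within the scatter).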

Compound 3, a percentage reported as activity, at one concentration (the size of the read-out at that concentration, not a potency): 20%
Compound 3: middle estimate off by 45 percentage points, on the high side; the measured number lies below the stated range.
By their numbers in this assay, from the lowest: compound 3; then compounds 2 and 1 (each within the scatter of the next).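

The saturated ring carbon looked tolerant while 4-hydroxyphenyl and 4-(dimethylamino)phenyl stood level there, but in this assay it proves sensitive to the aryl group it carries: 2,6-dichlorophenyl in place of 4-(dimethylamino)phenyl gives a large drop (a number 49.9 percentage points lower from compound 2 to compound 3 (beyond the scatter)), and in place of 4-hydroxyphenyl a drop of similar kind (a number 52 percentage points lower from compound 1 to compound 3 (beyond the scatter)). The tolerance seen with compound 1 and compound 2 therefore extends only to those two groups, not to every substituted phenyl on this carbon. Nothing measured here bears on what lies behind the drop.

On these data alone, whether the drop belongs to having two chlorine atoms or to where they sit stays open, and unsubstituted phenyl or 4-chlorophenyl on this carbon would separate the two readings. How a carboxylic acid or an amine on this phenyl ring would read is also unknown.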